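Swapping methyl for chloro on a triterpenoid ester pair

This account rests on a few compounds, and the source may have more. Where it says the series, first, only, none or still open, it means among the compounds named here.

Four compounds share a large polycyclic core with an ester of a para-substituted benzoic acid on one ring. Compound 1 `CC1=CC[C@H]2[C@H](CC[C@]2(C)O)C(C)(C)[C@@H]1CC[C@H]1[C@]2(C)CC[C@H](OC(=O)c3ccc(C)cc3)C(C)(C)O[C@H]2CC[C@@]1(C)O` carries the 4-methylphenyl ester; compound 2 `CC1=CC[C@H]2[C@H](CC[C@]2(C)O)C(C)(C)[C@@H]1CC[C@H]1[C@]2(C)CC[C@H](OC(=O)c3ccc(Cl)cc3)C(C)(C)O[C@H]2CC[C@@]1(C)O` differs by chloro in place of methyl on an aromatic carbon. Compound 3 `CC1=CC[C@H]2[C@@H]1CC=C(C)[C@@H](CC[C@H]1[C@]3(C)CC[C@H](OC(=O)c4ccc(C)cc4)C(C)(C)O[C@H]3CC[C@@]1(C)O)C2(C)C` is built on a different core, and the difference between the two cores is not broken down here; compound 4 `CC1=CC[C@H]2[C@@H]1CC=C(C)[C@@H](CC[C@H]1[C@]3(C)CC[C@H](OC(=O)c4ccc(Cl)cc4)C(C)(C)O[C@H]3CC[C@@]1(C)O)C2(C)C` differs from compound 3 by chloro in place of methyl on an aromatic carbon, the same change as from compound 1 to compound 2.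

Compound 1 was tested in a functional assay on MCF7 cells (Homo sapiens) for antiproliferative activity, read by MTT assay, with a stated time of 72 h (a higher number here means a weaker inhibitor, a lower number a stronger inhibitor), where it reaches only the limit of the measurement at > 50000 nM. Compound 2 gives 24100 nM in this assay. That amounts to an at least 2.0-fold lower number from compound 1 to compound 2 (0.31 log units; beyond the scatter). Compound 3, in this assay, likewise reaches only the limit at > 50000 nM.

Whether the chloro step repeats on the second core rests on compound 1 and compound 2 alone, and because of the limit of > 50000 nM in this assay, at which 2 of the 3 values shown sit, the size of that step is itself uncertain. Compound 4 is expected to show an at least 1.2-fold lower number from compound 3 to compound 4 (0.09 log units; that floor lies within the scatter), with an estimated value of 40000 nM, likely between 15000 nM and 200000 nM.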

Compound 4, half-maximal inhibitory concentration: 22000 nM
Compound 4: the middle estimate sits 1.8-fold (0.26 log units) above what was measured; the range from low to high includes it.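

On the second core, putting chloro in place of methyl again lowers the number in this assay, with an at least 2.2-fold lower number from compound 3 to compound 4 (0.35 log units; beyond the scatter), so the direction of the change carries over from one core to the other in these two pairs. Set side by side, the two steps compare as follows: the same change on two cores in this assay, an at least 2.0-fold lower number (0.31 log units; beyond the scatter) from compound 1 to compound 2 and an at least 2.2-fold lower number (0.35 log units; beyond the scatter) from compound 3 to compound 4; the limit leaves it open whether they differ. On these data alone, the true size of each step stays unknown, and so does whether one core responds more strongly than the other, because compound 1 and compound 3 both stop at a limit of the measurement rather than giving a number: the limit of > 50000 nM in this assay, at which 2 of the 4 values shown sit.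

The compounds shown leave open what a bromo, a methoxy or an amine in place of the chloro would do on either core, and whether an amide in place of the ester link would keep the step. A methyl ester with a true number instead of a limit would be needed to fix the size of the step on each core.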